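Aryl amine variation on the chlorotriazine core

The source may report more compounds than this note shows. Statements on the series, on what has been measured and on what is new or still open speak of the compounds shown alone.

Compound 3 `CCOC(=O)c1ccc(Nc2nnc(Cl)c(Nc3cc(OC)c(OC)c(OC)c3)n2)cc1` gives the highest number among the three measured compounds in a functional assay on PC-3 cells (Homo sapiens) for inhibition, read by MTT assay, with a stated time of 48 h (on this read-out higher numbers stand for weaker inhibition and lower numbers for stronger inhibition), at 58500 nM. Compound 1 `COc1cc(Nc2nc(Nc3ccc4c(ccn4C)c3)nnc2Cl)cc(OC)c1OC` gives 48500 nM, within the scatter of compound 3, while compound 2 `COc1cccc(Nc2nnc(Cl)c(Nc3cc(OC)c(OC)c(OC)c3)n2)c1` gives 11300 nM, beyond it. Among the compounds with values here, the one single-point step seen so far, a 4.3-fold lower number from compound 1 to compound 2 (0.63 log units; beyond the scatter), shows that the aryl amine group can shift the number by a modest amount. Compound 4 `COc1ccc(Nc2nnc(Cl)c(Nc3cc(OC)c(OC)c(OC)c3)n2)cc1` differs from compound 3 by methoxy in place of ethoxycarbonyl on an aromatic carbon. Within the data shown here, no measured step covers this exchange; the nearest guide is that a methoxyphenyl in compound 2 gives 11300 nM. A modest step to a lower number, a 2.9-fold lower number from compound 3 to compound 4 (0.47 log units; beyond the scatter), is therefore expected. For compound 4 the estimate in this assay is 20000 nM, with a range from 7000 nM to 60000 nM.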

Compound 4, half-maximal inhibitory concentration: 13500 nM
Compound 4: the middle estimate sits 1.5-fold (0.17 log units) above what was measured; the measured number falls inside the stated range.
By their numbers in this assay, from the lowest: compounds 2 and 4 (each within the scatter of the next); then compounds 1 and 3 (each within the scatter of the next).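

In this assay, methoxy in place of ethoxycarbonyl on this aromatic carbon gives the first step read directly at this position (a 4.3-fold lower number from compound 3 to compound 4 (0.64 log units; beyond the scatter)). The methoxy placement on the aniline ring does not separate 4-methoxyphenyl from 3-methoxyphenyl (a 1.2-fold higher number from compound 2 to compound 4 (0.08 log units; within the scatter)). 4-Methoxyphenyl also stands apart from 1-methyl-1H-indol-5-yl (a 3.6-fold lower number from compound 1 to compound 4 (0.56 log units; beyond the scatter)), as 3-methoxyphenyl did.

Nothing available explains these steps. From the compounds shown here alone, whether an amine, a carboxylic acid or a longer alkoxy chain on this aromatic carbon would read like methoxy or like ethoxycarbonyl remains open.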